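Methoxy on the anilide ring: compound 1 to compound 4

The compounds below may be only part of what the source reports. "The series", "measured", "known", "first", "only" and "open" are said of these compounds alone.

Three coumarin-type amides sharing one core have been measured in an ADME assay on MCF-10A cells (Homo sapiens) for cytotoxicity, read by MTT assay, with a stated time of 48 h; a lower number here means a stronger inhibitor, a higher number a weaker inhibitor. Compound 1 `COc1cc2cc(C(=O)Nc3ccccc3)c(=O)oc2cc1OCCCOc1no[n+]([O-])c1S(=O)(=O)c1ccccc1` gives 9670 nM. Compound 2 `COc1cc2cc(C(=O)NCCCc3ccccc3)c(=O)oc2cc1OCCCOc1no[n+]([O-])c1S(=O)(=O)c1ccccc1` gives 5330 nM, and compound 3 `COc1cc2cc(C(=O)NCCCc3ccc(F)cc3)c(=O)oc2cc1OCCCOc1no[n+]([O-])c1S(=O)(=O)c1ccccc1` gives 8920 nM. Compound 1 has the highest of the three numbers, but its steps of a 1.8-fold lower number from compound 1 to compound 2 (0.26 log units; within the scatter) and a 1.1-fold lower number from compound 1 to compound 3 (0.04 log units; within the scatter) both lie within the scatter, so the three compounds cannot be told apart on these data.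

Compound 4 `COc1ccc(NC(=O)c2cc3cc(OC)c(OCCCOc4no[n+]([O-])c4S(=O)(=O)c4ccccc4)cc3oc2=O)cc1` differs from compound 1 by methoxy in place of hydrogen on an aromatic carbon. Going by the values given here, no measured step puts a methoxy group onto this ring. The nearest analogy is a 1.7-fold higher number from compound 2 to compound 3 (0.22 log units; within the scatter), a single substituent entering an aromatic ring of a different side chain, which stayed within the scatter. Given that all three measured steps in this assay are within the scatter, compound 4 is expected to show a step of a 1.1-fold lower number from compound 1 to compound 4 (0.03 log units; within the scatter), that is, no change beyond the scatter. Compound 4 is therefore estimated at 9000 nM, with a range from 4500 nM to 20000 nM.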

Compound 4, half-maximal inhibitory concentration: 5470 nM
Compound 4: middle estimate off by 1.6-fold (0.22 log units), on the high side; the measured number falls inside the stated range.
By their numbers in this assay, from the lowest: compounds 2, 4, 3 and 1 (each within the scatter of the next).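

Putting methoxy onto the phenyl ring on the amide nitrogen gives a 1.8-fold lower number from compound 1 to compound 4 (0.25 log units; within the scatter) in this assay, so a substituent on this ring, para to a large group, has not moved the number beyond the scatter. Compound 4 also cannot be told apart from the two compounds with propyl-linked side chains: a 1.6-fold lower number from compound 3 to compound 4 (0.21 log units; within the scatter) and a 1.0-fold higher number from compound 2 to compound 4 (0.01 log units; within the scatter) both stay within the scatter, so 4-methoxyphenyl on the amide nitrogen reads the same here as 3-(4-fluorophenyl)propyl or 3-phenylpropyl. Nothing is available that would explain these numbers.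

On these data alone, it remains open whether an amine or a carboxylic acid at this same place would shift the number beyond the scatter. The compounds shown also leave open whether a longer chain in place of methoxy would do so.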